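Swapping a Methoxybenzyl Arm for Butyl

The source may report more compounds than this note shows. Statements on the series, on what has been measured and on what is new or still open speak of the compounds shown alone.

Compound 1 `CCOC(=O)c1ccc(-c2nn(Cc3ccccc3OC)c3ccccc23)cc1` carries an ethyl ester on a phenyl attached to the shared core, and a 2-methoxybenzyl on the core nitrogen. Going by the values given here, in a functional assay on cells (Platelet, Homo sapiens) for inhibition (on this read-out higher numbers stand for weaker inhibition and lower numbers for stronger inhibition), compound 1 gives 470 nM, the only outright number in this small set. Among the compounds with values here, compound 2 `CCOC(=O)c1cccc(-c2nn(Cc3ccccc3)c3ccccc23)c1` differs from compound 1 in more than one place, so no single step links the two. In this assay compound 2 gives only a limit of the assay, > 10000 nM, and so its strength is not known as a number. That result is the limit of > 10000 nM in this assay, at which 1 of the 2 values shown sits.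

Compound 3 `CCCCn1nc(-c2ccc(C(=O)OCC)cc2)c2ccccc21` changes the arm on the nitrogen: propyl in place of 2-methoxyphenyl on a saturated chain carbon bound to an aromatic nitrogen. Within the data shown here, no measured step of this kind exists here, so the size of the step is an expectation only. Losing the aromatic ring and its methoxy is expected to weaken inhibition, and the step of a 5.3-fold higher number from compound 1 to compound 3 (0.73 log units; beyond the scatter) is estimated to lie beyond the usual scatter. Compound 3 is therefore expected to give about 2500 nM, with a likely range from 700 nM to 9000 nM.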

Compound 3, half-maximal inhibitory concentration: 670 nM
The estimate for compound 3 lay 3.7-fold (0.57 log units) above the measured number; the measured number lies below the stated range.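

In this assay, replacing the 2-methoxybenzyl arm on the core nitrogen with butyl gives a 1.4-fold higher number from compound 1 to compound 3 (0.15 log units; within the scatter). In this pair, then, a plain chain with no ring and no oxygen serves as well as the 2-methoxybenzyl arm, so neither the aromatic ring nor the methoxy is needed for inhibition on the shared core with this ethyl ester phenyl group. Compound 2 differs from compound 3 in more than one place, so it cannot test this swap, and its result is only a limit of the assay: the limit of > 10000 nM in this assay, at which 1 of the 3 values shown sits.

The compounds shown leave open how much the length of the chain matters, for example whether a longer chain such as hexyl would behave like butyl. They also leave open whether a butyl chain ending in an amine, or a carboxylic acid in place of the ethyl ester, would keep this inhibition.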